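A few compounds are considered here, and "the series" means these few. Any claim that something is new, unique, unknown or untested is made for them only; others in the source may bear on it.

Measured in a functional assay on A549 cells (Homo sapiens) for antiproliferative activity, read by MTT assay, with a stated time of 72 h; a lower number here means a stronger inhibitor, a higher number a weaker inhibitor:
- Compound 1 `NC1=NC2(CCOCC2)N(OCCCOc2cccc(Cl)c2Cl)C(N)=N1`: 100 nM
- Compound 2 `NC1=NC2(CCOCC2)N(OCCCOc2ccc(Cl)c(Cl)c2)C(N)=N1`: 790 nM

Of these two, compound 2 has the higher number, 790 nM. Compound 3 `NC1=NC2(CCOCC2)N(OCCCOc2cccc(Cl)c2)C(N)=N1` differs from it as follows: hydrogen in place of chloro on an aromatic carbon, taking 3,4-dichlorophenyl to 3-chlorophenyl. Within the data shown here, only one measured step bears on this, a 7.9-fold higher number from compound 1 to compound 2 (0.90 log units; beyond the scatter), and it exchanges one dichlorophenyl pattern for another without removing a chloro. It shows that this assay responds to the chloro pattern, but it gives no direct size for this change. A small move toward a lower number is therefore expected, namely a 1.6-fold lower number from compound 2 to compound 3 (0.20 log units; within the scatter). Compound 3 is estimated at 500 nM, with an expected range of 150 nM to 1600 nM.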

Compound 3, half-maximal inhibitory concentration: 150 nM
The estimate for compound 3 lay 3.3-fold (0.52 log units) above the measured number; the measured number falls inside the stated range.
By their numbers in this assay, from the lowest: compounds 1 and 3 (each within the scatter of the next); then compound 2.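

In this assay, the chloro para to a large group matters: its replacement by hydrogen gives a 5.3-fold lower number from compound 2 to compound 3 (0.72 log units; beyond the scatter). The same kind of exchange starting from 2,3-dichlorophenyl gives a 1.5-fold higher number from compound 1 to compound 3 (0.18 log units; within the scatter), so the size of this change depends on which chloro leaves. Nothing available explains this difference. The compounds shown leave open whether a fluoro or methoxy group in that place would go with the higher number of compound 2 or stay near compound 3, and how a longer chain would alter the picture.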